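Diethylamide in Place of Primary Amide on the Shared Core

A few compounds are considered here, and "the series" means these few. Any claim that something is new, unique, unknown or untested is made for them only; others in the source may bear on it.

Compound 3 `CC1=C(C(N)=O)C(c2ccoc2)NC(=O)N1` gives the lowest number of the three measured compounds in an assay on membranes from HEK293 cells for displacement of a labelled ligand from adenosine receptor A2b (Homo sapiens), read by scintillation counting, with a stated time of 30 min, tested at 1 uM (a lower number here means less inhibition, a higher number more inhibition at the concentration tested (going by the name of the read-out)), at 6%. Within the data shown here, its nearest neighbour is compound 1 `CC(=O)C1=C(C)NC(=O)NC1c1ccoc1`, which gives 15%; the only step that touches compound 3 directly is a number 9 percentage points lower from compound 1 to compound 3 (within the scatter). Compound 2 `CCN(CC)C(=O)C1=C(C)NC(=O)NC1c1ccco1` gives 31%, the furthest value. Compound 4 `CCN(CC)C(=O)C1=C(C)NC(=O)NC1c1ccoc1` differs from compound 3 by diethylamino in place of amino on a carbonyl carbon. Among the measured compounds shown here, no measured step shares this change on the same core, so the expectation rests on what the values of compound 2 and compound 3 show. Compound 4 is therefore estimated to show a rise beyond the scatter, a number 16 percentage points higher from compound 3 to compound 4 (beyond the scatter), to about 22%, within a range of 5% to 40%.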

Compound 4, a percentage reported as inhibition, at one concentration (the size of the read-out at that concentration, not a potency): 12%
For compound 4 the middle estimate is 10 percentage points above the measured one; the measured number falls inside the stated range.
By their numbers in this assay, from the lowest: compounds 3, 4 and 1 (each within the scatter of the next); then compound 2.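

In this assay, diethylamino on the carbonyl carbon cannot be told apart from amino (a number 6 percentage points higher from compound 3 to compound 4 (within the scatter)) or from methyl (a number 3 percentage points lower from compound 1 to compound 4 (within the scatter)), so changing this group on the furan-3-yl compounds shows no effect beyond the scatter. The change that does exceed the scatter lies elsewhere: with the diethylamide held constant, furan-3-yl in place of furan-2-yl on the saturated ring carbon gives a clear drop (a number 19 percentage points lower from compound 2 to compound 4 (beyond the scatter)).

Going by these compounds, whether a phenyl group on that ring carbon, or a dipropylamino group on the carbonyl carbon, would move the number remains open. No evidence is available to explain why the furan attachment matters here.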